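The compounds below may be only part of what the source reports. "The series", "measured", "known", "first", "only" and "open" are said of these compounds alone.

In a functional assay on HGC-27 cells (Homo sapiens) for cytotoxicity, read by MTT assay, with a stated time of 48 h (a lower number here means a stronger inhibitor, a higher number a weaker inhibitor), compound 1 `COc1ccc(/C=C/C(=O)/C=C/c2cc3ccccc3nc2Cl)cc1` gives > 10000 nM, which is a limit of the assay and not a number. Compound 2 `COc1ccc(/C=C/C(=O)/C=C/c2cc3ccccc3nc2Cl)c(OC)c1` differs from compound 1 by methoxy in place of hydrogen on an aromatic carbon. In this assay compound 2 gives > 10000 nM, again a limit. The step that the two limits leave unreadable from compound 1 to compound 2 is therefore not readable. Compound 3 `COc1ccc(/C=C/C(=O)/C=C/c2cc3ccccc3nc2Oc2cccc(Cl)c2)cc1OC` rests on a different core; the difference between the two cores is not broken down here. In this assay compound 3 gives > 10000 nM, a limit as well. All three values sit at the same point, as the limit of > 10000 nM in this assay, at which 3 of the 3 values shown sit, records. Compound 4 `COc1cc(OC)c(OC)cc1/C=C/C(=O)/C=C/c1cc2ccccc2nc1Oc1cccc(Cl)c1` is not yet measured and differs from compound 3 by methoxy in place of hydrogen on an aromatic carbon. This is the same kind of change as that from compound 1 to compound 2, not the same: around its place the entering methoxy is also para to a methoxy group, which is not so for compound 2. Because the limit of > 10000 nM in this assay, at which 3 of the 3 values shown sit, places every value at the limit, no change in this set has a readable size. Compound 4 is expected to stay near that limit, with an estimated step that the limit leaves unreadable from compound 3 to compound 4. In this assay compound 4 is expected to give about 20000 nM, estimated between 5000 nM and 100000 nM.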

Compound 4, half-maximal inhibitory concentration: > 10000 nM
Compound 4 ended at the assay's limit; the forecaster's own chance of this, stated with the estimate: 85%; the middle value is on the limit's open side.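

Compound 3 and compound 4 both sit at a limit of this assay, so the step between them cannot be read, and neither can any other step in this set: the limit of > 10000 nM in this assay, at which 4 of the 4 values shown sit.

The compounds shown leave open how far each lies past that limit, and whether methoxy in place of hydrogen on an aromatic carbon changes the result in this assay at all.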